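Swapping the benzyl halide for isobutyl on the shared core

The source may report more compounds than this note shows. Statements on the series, on what has been measured and on what is new or still open speak of the compounds shown alone.

Measured compounds:
compound 1 `COc1ccc(F)cc1CNCCCNc1ccnc2cc(Cc3ccc(F)cc3Cl)ccc12` — 23 10^-6 cm/s
compound 2 `COc1ccc(-c2ccc3c(NCCCNCc4ccco4)ccnc3c2)cc1` — 237 10^-6 cm/s
compound 3 `Fc1ccc(Cc2ccc3c(NCCCNCc4ccco4)ccnc3c2)c(Cl)c1` — 23 10^-6 cm/s

In an ADME assay for permeability, using PAMPA, with a stated time of 30 min, at pH 7.4 (on this read-out higher numbers stand for higher permeability and lower numbers for lower permeability), compound 1 stands level with compound 3, with no change at the digits printed from compound 1 to compound 3 (within the scatter), and together they give the lowest numbers of the three; the gap from each of them to compound 2 is a large one. Compound 4 `COc1ccc(F)cc1CNCCCNc1ccnc2cc(CC(C)C)ccc12` differs from compound 1 by isopropyl in place of 2-chloro-4-fluorophenyl on a saturated chain carbon bound to an aromatic carbon. Within the data shown here, the only measured step at that position is a 10-fold lower number from compound 2 to compound 3 (1.01 log units; beyond the scatter), and no change at the digits printed from compound 1 to compound 3 (within the scatter) shows the amine-side change leaving this assay unmoved. Among the measured compounds shown here, no measured pair bears on isopropyl here, so compound 4 is expected to move by a 1.5-fold higher number from compound 1 to compound 4 (0.18 log units; within the scatter), at most a modest rise. Compound 4 is estimated at 35 10^-6 cm/s, between 10 10^-6 cm/s and 110 10^-6 cm/s.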

Compound 4, apparent permeability: 23 10^-6 cm/s
For compound 4 the middle estimate is 1.5-fold (0.18 log units) above the measured one; the measured number falls inside the stated range.
By their numbers in this assay, from the lowest: compounds 1, 3 and 4 (each within the scatter of the next); then compound 2.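

In this assay, replacing 2-chloro-4-fluorobenzyl with isobutyl gives no change at the digits printed from compound 1 to compound 4 (within the scatter). The earlier step at this place, a 10-fold lower number from compound 2 to compound 3 (1.01 log units; beyond the scatter), had replaced 4-methoxyphenyl and was large, whereas this change, which removes the six-membered aromatic ring of carbon only and both halogens from the saturated chain carbon, leaves the number level. No supporting evidence accounts for this level result. Still open, on these data alone, is whether an amine or a carboxylic acid on this saturated chain carbon would stay level, and whether isobutyl would do so alongside furan-2-yl on the amine side.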